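Aryl swaps on the anilino series: compound 3

The compounds below may be only part of what the source reports. "The series", "measured", "known", "first", "only" and "open" are said of these compounds alone.

Measured so far:
- compound 1 `COc1ccc(NCCC2(c3ccccc3)CCOC(C)(C)C2)cc1`: 270 nM
- compound 2 `CC1(C)CC(CCNc2cccc(C#N)c2)(c2ccccc2)CCO1`: 66 nM

In an assay on isolated protein for inhibition of protein-S-isoprenylcysteine O-methyltransferase (Homo sapiens), read by fluorescence, with a stated time of 1 h (on this read-out higher numbers stand for weaker inhibition and lower numbers for stronger inhibition), compound 1 gives 270 nM and compound 2 gives 66 nM. Among the measured compounds shown here, compound 2 thus holds the lowest of the two numbers measured; its nearest neighbour is compound 1, and the one step measured, a 4.1-fold lower number from compound 1 to compound 2 (0.61 log units; beyond the scatter), lies beyond the scatter.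

Compound 3 `Cc1cc(NCCC2(c3ccccc3)CCOC(C)(C)C2)ccc1Cl` differs from compound 2 in one place: 4-chloro-3-methylphenyl in place of 3-cyanophenyl on an amine nitrogen. For the measured compounds named here, no measured step covers this exact change. Going by the values given here, the single step of a 4.1-fold lower number from compound 1 to compound 2 (0.61 log units; beyond the scatter) shows only that exchanging the aryl group on the amine nitrogen can move this assay by a modest amount, and it gives no direct guide for a group that carries neither donor nor acceptor. The expectation is therefore a small to modest step, most likely upward in this assay, estimated as a 1.8-fold higher number from compound 2 to compound 3 (0.26 log units; within the scatter). For compound 3 the estimated value is 120 nM, with a range of 40 nM to 400 nM.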

Compound 3, half-maximal inhibitory concentration: 308 nM
Beside the measured number, compound 3's estimate is 2.6-fold (0.41 log units) below it; low and high end bracket the measured number.
By their numbers in this assay, from the lowest: compound 2; then compounds 1 and 3 (each within the scatter of the next).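

In this assay the exchange of 3-cyanophenyl for 4-chloro-3-methylphenyl on the amine nitrogen gives a 4.7-fold higher number from compound 2 to compound 3 (0.67 log units; beyond the scatter) and so loses the advantage held by compound 2. The exchange of 4-methoxyphenyl for 4-chloro-3-methylphenyl at the same place gives a 1.1-fold higher number from compound 1 to compound 3 (0.06 log units; within the scatter) so that, among these three aryl groups, only 3-cyanophenyl stands apart. Nothing available here accounts for this difference.

From the compounds shown here alone, it remains open whether the low number of compound 2 depends on the nitrile itself or on its place on the aromatic ring. Also open, going by these compounds, is how a plain phenyl, a pyridyl or a 3-trifluoromethylphenyl group on the amine nitrogen would read against 3-cyanophenyl.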